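A Second Demethylation Tested for Cytotoxic Potency

The source may hold more compounds than are shown below. What is called first, only, known or untested is meant among the compounds shown, and "the series" means these compounds.

Two compounds have been measured in a functional assay on cells (Lung cancer cell line, Homo sapiens) for cytotoxicity; a lower number here means that less compound is needed, a higher number that more compound is needed for the effect:
compound 1 `COC1=C(OC)[C@@]2(OC)c3c(OC)c(OC)c4c(c3O[C@@]23O[C@@H](c2ccccc2)CC=C3C1=O)[C@@H](OC)C[C@H](c1ccccc1)O4`: 0.7 ug/mL
compound 2 `COC1=C(OC)[C@@]2(OC)c3c(O)c(OC)c4c(c3O[C@@]23O[C@@H](c2ccccc2)CC=C3C1=O)[C@@H](OC)C[C@H](c1ccccc1)O4`: 1.2 ug/mL

Among the compounds with values here, compound 2 gives the highest of these two numbers, though its only neighbour, compound 1, lies within the scatter, as the step of a 1.7-fold higher number from compound 1 to compound 2 (0.23 log units; within the scatter) shows. Compound 3 `COC1=C(OC)[C@@]2(OC)c3c(O)c(OC)c4c(c3O[C@@]23O[C@@H](c2ccccc2)CC=C3C1=O)[C@@H](O)C[C@H](c1ccccc1)O4` is not yet measured; it differs from compound 2 by hydrogen in place of methyl on an oxygen on a saturated carbon. Within the data shown here, the only step available, from compound 1 to compound 2, also exchanged a methyl on an oxygen for hydrogen and stayed within the scatter, so no shift beyond the scatter is expected here either: the estimated step is a 1.3-fold higher number from compound 2 to compound 3 (0.10 log units; within the scatter). Compound 3 is therefore expected at 1.5 ug/mL, within 0.6 ug/mL to 4 ug/mL.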

Compound 3, half-maximal effective concentration: 1.6 ug/mL
Estimate against measurement, compound 3: 1.1-fold (0.03 log units) below, and the stated range covers the measured number.
By their numbers in this assay, from the lowest: compounds 1, 2 and 3 (each within the scatter of the next, the first and the last beyond it).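

In this assay, replacing methoxy with hydroxy on an oxygen on a saturated carbon gives a 1.3-fold higher number from compound 2 to compound 3 (0.12 log units; within the scatter). This second place, distinct from the aromatic one changed earlier, therefore also accepts hydrogen in place of methyl without a shift beyond the scatter. No available data bear on why the number stays within the scatter here. The compounds shown leave open whether an ethyl ether or a longer chain on this oxygen would do the same. They also leave open how an amine in place of the hydroxy would read.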